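The source may report more compounds than this note shows. Statements on the series, on what has been measured and on what is new or still open speak of the compounds shown alone.

Three compounds built on a shared core with an amide attached were tested in a toxicity assay on THP-1 cells (Homo sapiens) for inhibition; a lower number here means that less compound is tolerated, a higher number that more compound is tolerated. Compound 1 `COc1ccccc1-c1cnc(NC(=O)c2ccc(F)cc2)n1C` reached only a limit of the assay in this assay, > 100000 nM. Compound 2 `COc1ccc(-c2cnc(NC(=O)c3ccccc3F)n2C)cc1` likewise gave only a limit in this assay, > 100000 nM. Compound 3 `COc1ccc2c(c1)nc(NC(=O)c1ccc(F)cc1)n2C` also stopped at the limit in this assay, > 100000 nM. Compound 2 thus stands where the other two stand: its value is a limit and not a number, and the two further values shown are limits as well, so nothing separates the three (the limit of > 100000 nM in this assay, at which 3 of the 3 values shown sit). Among the compounds with values here, no step between measured compounds that differ in one place is available, and so no measured step sets a scale for what a single change does here.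

Compound 4 `COc1ccc(-c2cnc(NC(=O)c3cccc(Br)c3)n2C)cc1` has not yet been measured in this assay. It differs from compound 2 in one place:

3-bromophenyl in place of 2-fluorophenyl on a carbonyl carbon

With every value shown sitting at the limit (the limit of > 100000 nM in this assay, at which 3 of the 3 values shown sit), the step expected in this assay is a number no higher from compound 2 to compound 4 (the limit leaves the size open), none beyond the scatter. Compound 4 is therefore expected in this assay to give about 100000 nM, within 50000 nM to 200000 nM, most likely once more as a limit rather than a number.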

Compound 4, half-maximal cytotoxic concentration: > 100000 nM
Compound 4 was reported as a limit; the forecaster's own chance of this, stated with the estimate: 85%; the middle value lies on the limit itself.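

Within the data shown here, compound 2 and compound 4 both stand at a limit in this assay, so the swap of 2-fluorophenyl for 3-bromophenyl gives no step that can be read: the limit of > 100000 nM in this assay, at which 4 of the 4 values shown sit. The compounds shown leave open what any single change on the shared core does in this assay, as none of them yet gives a number.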